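A few compounds are considered here, and "the series" means these few. Any claim that something is new, unique, unknown or untested is made for them only; others in the source may bear on it.

Measured so far in a functional assay on HEK293 cells for agonist activity at Neuronal acetylcholine receptor; alpha4/beta2 (Homo sapiens), read by FLIPR; a higher number here means that more compound is needed for the effect, a lower number that less compound is needed:
Compound 1 `c1cncc(N2C[C@@H]3CCNC[C@@H]32)c1` gives 410 nM.
Compound 2 `COc1cc(N2C[C@@H]3CCNC[C@@H]32)cnc1Br` gives 1690 nM.
Compound 3 `N#Cc1cncc(N2C[C@@H]3CCNC[C@@H]32)c1` gives 2190 nM.

Compound 3 sits at the upper end of these three numbers; its value and that of compound 2 lie within the scatter of each other, while the step of a 5.3-fold higher number from compound 1 to compound 3 (0.73 log units; beyond the scatter) is beyond it. Compound 4 `N#Cc1cc(N2C[C@@H]3CCNC[C@@H]32)cnc1Br` carries bromo in place of hydrogen on an aromatic carbon. Going by the values given here, no measured pair isolates a bromo addition: compound 2 differs from compound 1 in two places, and its value is within the scatter of compound 3. Among the compounds with values here, the data give no single step bearing on this change, so no shift beyond the scatter is expected in this assay; the expected step is a 1.1-fold higher number from compound 3 to compound 4 (0.06 log units; within the scatter). For compound 4 the estimate is 2500 nM, with a range from 1000 nM to 6500 nM.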

Compound 4, half-maximal effective concentration: 109 nM
The estimate for compound 4 lay 23-fold (1.36 log units) above the measured number; measured number outside the range, below it.
By their numbers in this assay, from the lowest: compound 4; then compound 1; then compounds 2 and 3 (each within the scatter of the next).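

In this assay bromo on the aromatic carbon next to the ring nitrogen and ortho to a cyano group gives a 20-fold lower number from compound 3 to compound 4 (1.30 log units; beyond the scatter) and thus marks this position as highly sensitive when the nitrile is present. With bromo kept, cyano in place of methoxy gives a 16-fold lower number from compound 2 to compound 4 (1.19 log units; beyond the scatter) and shows that the outcome with bromo depends on the other ring substituent. No measured property accounts for either step. 

Going by these compounds, whether bromo gives a similar step without the cyano group remains open. Also open, on these data alone, is whether chloro, methyl or an amine at this carbon would match bromo.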